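The source may report more compounds than this note shows. Statements on the series, on what has been measured and on what is new or still open speak of the compounds shown alone.

In a functional assay on MGC-803 cells (Homo sapiens) for antiproliferative activity, read by MTT assay, with a stated time of 72 h (on this read-out higher numbers stand for weaker inhibition and lower numbers for stronger inhibition), compound 1 `O=C(COc1ccc(C(=O)/C=C/c2ccccc2Cl)cc1)N[C@H]1CCOC1=O` gives 27100 nM, and compound 2 `C=CCc1ccc(OCCSC(=S)N[C@H]2CCOC2=O)c(OC)c1` gives 27900 nM. The two numbers sit within the scatter of each other, so compound 1 stands level with its only companion rather than apart from it. Compound 3 `O=C(COc1ccc(C(=O)/C=C/c2cccc(F)c2)cc1)N[C@H]1CCOC1=O` differs from compound 1 in one place: 3-fluorophenyl in place of 2-chlorophenyl on a double-bonded chain carbon bound to a double-bonded chain carbon. Among the measured compounds shown here, no measured pair shows this swap. The expected step of a 1.1-fold higher number from compound 1 to compound 3 (0.04 log units; within the scatter) is therefore a small one, with no change beyond the scatter in either direction. In this assay compound 3 is estimated at 30000 nM, with a range from 12000 nM to 75000 nM.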

Compound 3, half-maximal inhibitory concentration: > 64000 nM
Compound 3: only a limit was reported; the forecaster's own chance of this, stated with the estimate: 5%; middle value at least 2.1-fold (0.32 log units) away from the limit.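

In this assay, 3-fluorophenyl in place of 2-chlorophenyl on a double-bonded chain carbon bound to a double-bonded chain carbon is not a neutral swap: it gives an at least 2.3-fold higher number from compound 1 to compound 3 (0.37 log units; beyond the scatter). Among the compounds shown here, this shows that the aromatic group at this place affects the read-out, which the earlier compounds could not show. The reading for compound 3 is a limit and not a number, so the full size of the step remains unknown: the limit of > 64000 nM in this assay, at which 1 of the 3 values shown sits.

The halogen and its place on the ring change together here, so their contributions cannot be separated. Going by these compounds, how a plain phenyl or an amine on this ring would compare remains open.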